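Aryl ether variation on a pyrrolidine acetic acid scaffold

A few compounds are considered here, and "the series" means these few. Any claim that something is new, unique, unknown or untested is made for them only; others in the source may bear on it.

Two compounds share a pyrrolidine acetic acid core bearing a trifluoromethyl group and differ in the group attached to the phenyl ring. Compound 1 `Cc1ccccc1Cc1ccc(N2C[C@@H](C(F)(F)F)C[C@H]2CC(=O)O)cc1` carries a 2-methylbenzyl group, and in a functional assay on cells for agonist activity at Free fatty acid receptor 1 (Mus musculus), read by FLIPR and calcium flux, with a stated time of 100 s (a higher number here means that more compound is needed for the effect, a lower number that less compound is needed), compound 1 gives 710 nM. Compound 2 `O=C(O)C[C@@H]1C[C@H](C(F)(F)F)CN1c1ccc(Oc2ccccc2C(F)(F)F)cc1` carries a 2-(trifluoromethyl)phenyl ether instead, and in this assay compound 2 gives 1300 nM. The two numbers sit close together, and the gap between compound 2 and compound 1 lies within the scatter of this kind of measurement, so compound 2 stands alongside compound 1 rather than apart from it.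

Compound 3 `Cc1c(Cl)cccc1Oc1ccc(N2C[C@@H](C(F)(F)F)C[C@H]2CC(=O)O)cc1` keeps the ether link of compound 2 but changes the aryl group: 3-chloro-2-methylphenyl in place of 2-(trifluoromethyl)phenyl on an oxygen on an aromatic ring. For the measured compounds named here, no measured pair shows what such an exchange does on this core. The chlorine and methyl substituents enter without adding donors or acceptors, and the expectation is that the number in this assay moves little, if at all, beyond the scatter, with a step of a 1.4-fold lower number from compound 2 to compound 3 (0.16 log units; within the scatter) expected. Compound 3 is therefore estimated at 900 nM, within a range from 300 nM to 2700 nM.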

Compound 3, half-maximal effective concentration: 430 nM
Compound 3: the middle estimate sits 2.1-fold (0.32 log units) above what was measured; measured number inside the range.
By their numbers in this assay, from the lowest: compounds 3, 1 and 2 (each within the scatter of the next, the first and the last beyond it).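

On an oxygen on an aromatic ring, 3-chloro-2-methylphenyl in place of 2-(trifluoromethyl)phenyl gives a 3.0-fold lower number from compound 2 to compound 3 (0.48 log units; beyond the scatter) in this assay, the first step among these compounds to lie beyond the scatter, so the aryl group on the ether oxygen does bear on this number, if only modestly. The exchange of 2-methylbenzyl for 3-chloro-2-methylphenoxy on an aromatic carbon gives a 1.7-fold lower number from compound 1 to compound 3 (0.22 log units; within the scatter), which lies within the scatter, so this pair does not separate the two groups in this assay. No measurement shown here explains either step.

The compounds shown leave open which part of the exchange carries the step from the trifluoromethyl compound, as the chlorine and the methyl enter together while the trifluoromethyl leaves, and no compound shows any of these substituents changed on its own. They also leave open how the number in this assay would respond to a methoxy group or a nitrile on the same aryl ring, and whether the step seen at this mouse receptor would carry over to the human receptor.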